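This account rests on a few compounds, and the source may have more. Where it says the series, first, only, none or still open, it means among the compounds named here.

Measured so far:
compound 1 `CN1CCN(Cc2nnc(-c3cc(S(N)(=O)=O)c(SCc4ccccc4)cc3Cl)o2)CC1`, 75000 nM
compound 2 `NS(=O)(=O)c1cc(-c2nnc(/C=C/c3c(Cl)cccc3Cl)o2)c(Cl)cc1SCc1ccccc1`, 12000 nM

For the measured compounds named here, in a functional assay on HeLa cells (Homo sapiens) for cytotoxicity, read by MTT assay, with a stated time of 72 h (a higher number here means a weaker inhibitor, a lower number a stronger inhibitor), compound 2 gives the lowest of the two numbers, with compound 1 the only neighbour; the step of a 6.3-fold lower number from compound 1 to compound 2 (0.80 log units; beyond the scatter) is the sole measured change. Compound 3 `NS(=O)(=O)c1cc(-c2nnc(/C=C/c3ccc(Br)cc3)o2)c(Cl)cc1SCc1ccccc1` differs from compound 2 by 4-bromophenyl in place of 2,6-dichlorophenyl on a double-bonded chain carbon bound to a double-bonded chain carbon. Going by the values given here, no measured step touches this part of the molecule, so the one step cannot guide the direction. The change is expected to stay near compound 2, at a 1.3-fold higher number from compound 2 to compound 3 (0.10 log units; within the scatter). Compound 3 is therefore estimated at 15000 nM, between 5000 nM and 45000 nM.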

Compound 3, half-maximal inhibitory concentration: 29000 nM
For compound 3 the middle estimate is 1.9-fold (0.29 log units) below the measured one; measured number inside the range.
By their numbers in this assay, from the lowest: compound 2; then compound 3; then compound 1.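

In this assay, the group on this chain carbon does affect the number: 4-bromophenyl in place of 2,6-dichlorophenyl gives a 2.4-fold higher number from compound 2 to compound 3 (0.38 log units; beyond the scatter). 2-(4-bromophenyl)ethenyl in place of (4-methylpiperazin-1-yl)methyl still gives a 2.6-fold lower number from compound 1 to compound 3 (0.41 log units; beyond the scatter), so the lower number relative to compound 1 is not unique to compound 2, although it is smaller here. No measurement available here explains either step. The swap removes two chlorines and adds one bromine, so the compounds shown leave open which of these changes matters. Plain phenyl or 4-chlorophenyl on the same chain could help separate them.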